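Phenyl for methyl on the tetrazole ring of compound 2

The source may report more compounds than this note shows. Statements on the series, on what has been measured and on what is new or still open speak of the compounds shown alone.

The series of three measured compounds was tested in a functional assay on C6 cells (Rattus norvegicus) for cytotoxicity, read by MTT assay, with a stated time of 24 h, tested at 200 ug/mL; on this read-out lower numbers stand for a stronger effect and higher numbers for a weaker effect at the one concentration tested. Compound 1 `Cc1ccc(-c2cs/c(=N/NC(=O)CSc3nnnn3-c3ccccc3)n2-c2ccccc2)cc1` gives 22.2%, compound 2 `Cn1nnnc1SCC(=O)N/N=c1/scc(-c2ccccc2)n1-c1ccccc1` gives 26.8%, and compound 3 `O=C(CSc1ncccn1)N/N=c1/scc(-c2ccc(Br)cc2)n1-c1ccccc1` gives 63.2%. Compound 2 stands second highest of the three; its nearest neighbour is compound 1, within the scatter, and its furthest is compound 3, beyond the scatter. The unmeasured compound 4 `O=C(CSc1nnnn1-c1ccccc1)N/N=c1/scc(-c2ccccc2)n1-c1ccccc1` differs from compound 2 in one place: phenyl in place of methyl on an aromatic nitrogen. For the measured compounds named here, no measured step of this kind exists. The same 1-phenyl-1H-tetrazol-5-yl group is present in compound 1, whose value sits within the scatter of compound 2, so the step from compound 2 to compound 4 is expected to be small, a number 2.8 percentage points lower from compound 2 to compound 4 (within the scatter), not beyond the scatter. Compound 4 is therefore estimated at 24%, with a range from 12% to 40%.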

Compound 4, a percentage reported as activity, at one concentration (the size of the read-out at that concentration, not a potency): 22.6%
The estimate for compound 4 lay 1.4 percentage points above the measured number; low and high end bracket the measured number.
By their numbers in this assay, from the lowest: compounds 1, 4 and 2 (each within the scatter of the next); then compound 3.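

In this assay, for the compounds shown here, 1-phenyl-1H-tetrazol-5-yl in place of 1-methyl-1H-tetrazol-5-yl gives a number 4.2 percentage points lower from compound 2 to compound 4 (within the scatter), the first measured step at this aromatic nitrogen, and the much larger phenyl group does not carry the number beyond the scatter. Hydrogen in place of methyl on an aromatic carbon gives a number 0.4 percentage points higher from compound 1 to compound 4 (within the scatter), so that change also stays within the scatter with this phenyl group in place. Nothing here gives a reason for either step. Still open, as far as these compounds go, is whether a longer chain or a carboxylic acid on this nitrogen would move the number beyond the scatter.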